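One solubility number and a swap on the core

The source may hold more compounds than are shown below. What is called first, only, known or untested is meant among the compounds shown, and "the series" means these compounds.

Compound 1 `N#Cc1cnc(NC(=O)CCCOc2ccccc2)s1`: 1100 nM
Compound 2 `Cc1cnc(NC(=O)CCCOc2cccc(C#N)c2)s1`: < 1100 nM (a limit, not a number)

Going by the values given here, in a physicochemical assay for solubility, read by nephelometry, at pH 2 (on this read-out lower numbers stand for lower solubility and higher numbers for higher solubility), compound 1 gives 1100 nM, the only true number so far. Compound 2 gives < 1100 nM, which is a limit of the assay and not a number. Among the compounds with values here, no two measured compounds differ in just one place, so there is no measured step to lean on. Compound 3 `CC(C)c1cnc(NC(=O)CCCOc2ccccc2)s1` has not yet been measured. It differs from compound 1 by a single change: isopropyl in place of cyano on an aromatic carbon next to the ring sulfur. The expectation in this assay is a step no larger than the usual scatter, downward if anything, and a report as a limit is quite possible. The estimated step runs a 1.2-fold lower number from compound 1 to compound 3 (0.09 log units; within the scatter), a small one. For compound 3 the expected value is 900 nM, with an estimated range from 400 nM to 2500 nM for the measurement still to come.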

Compound 3, solubility: < 1200 nM
Compound 3 gave a limit, no number; the forecaster's own chance of this, stated with the estimate: 55%; the middle value is on the limit's open side.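

In this assay compound 3 gives < 1200 nM, a limit of the assay and not a number. Going by these compounds alone, no step from compound 1 to compound 3 can be read from it. The compounds shown leave open what size and direction of step goes with isopropyl in place of cyano on an aromatic carbon.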